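The compounds below may be only part of what the source reports. "The series", "measured", "known", "first", "only" and "open" are said of these compounds alone.

In a functional assay on DLD-1 cells (Homo sapiens) for antiproliferative activity, read by CellTiter-Glo, with a stated time of 72 h (on this read-out lower numbers stand for stronger inhibition and higher numbers for weaker inhibition), compound 3 (`CC1CCN(C2CCN(S(=O)(=O)c3cn(C)cn3)CC2)CC1`) gives only a limit, > 5000 nM. Compound 1 (`COc1cccc(S(=O)(=O)N2CCC(N3CCC(C)CC3)CC2)c1`) also gives only a limit, > 5000 nM. That limit is the limit of > 5000 nM in this assay, at which 2 of the 3 values shown sit. Compound 2 (`Cc1cc(S(=O)(=O)N2CCC(N3CCC(C)CC3)CC2)c(Cl)cc1Cl`) instead gives a true number, 2 nM.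

Compound 4 (`CC1CCN(C2CCN(S(=O)(=O)c3ccc(Cl)cc3Cl)CC2)CC1`) keeps the core of compound 3 but carries 2,4-dichlorophenyl in place of 1-methyl-1H-imidazol-4-yl on a sulfonyl sulfur.

Within the data shown here, the one measured step at this place is a step that the two limits leave unreadable from compound 1 to compound 3, so it offers no size to carry over. Among the measured compounds shown here, the better guide is compound 2 at 2 nM, the only compound here with chlorine on the ring at the sulfonyl sulfur and the only one that gives a number. This rests on a single compound, so the expectation stays wide. A large move toward stronger inhibition is expected in this assay, with an estimated step of an at least 330-fold lower number from compound 3 to compound 4 (2.52 log units; beyond the scatter). The estimate for compound 4 is 15 nM. The expected range for compound 4 runs from 3 nM to 150 nM.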

Compound 4, half-maximal inhibitory concentration: 1 nM
The estimate for compound 4 lay 15-fold (1.18 log units) above the measured number, outside the stated range (below it).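

The group on the sulfonyl sulfur now has a readable effect in this assay: 2,4-dichlorophenyl in place of 1-methyl-1H-imidazol-4-yl gives an at least 5000-fold lower number from compound 3 to compound 4 (3.69 log units; beyond the scatter), and 2,4-dichlorophenyl in place of 3-methoxyphenyl gives an at least 5000-fold lower number from compound 1 to compound 4 (3.69 log units; beyond the scatter). Compound 1 and compound 3 each give only a limit, not a true number: the limit of > 5000 nM in this assay, at which 2 of the 4 values shown sit. Hydrogen in place of the methyl of compound 2 gives a 2.0-fold lower number from compound 2 to compound 4 (0.30 log units; within the scatter), so strong inhibition no longer rests on a single compound and does not depend on that methyl.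

As far as these compounds go, it remains open whether both chlorines are needed, or whether one would do. A phenyl ring carrying a single chlorine, or bromine or trifluoromethyl in place of chlorine, would show how much of the effect belongs to each chlorine and to chlorine itself.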